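Piperidine series: replacing an aryloxy arm, tolerance on PBMC cells

This account rests on a few compounds, and the source may have more. Where it says the series, first, only, none or still open, it means among the compounds named here.

Of the compounds shown here, two have been measured in an ADME assay on PBMC cells (Homo sapiens) for cytotoxicity; a higher number here means that more compound is tolerated, a lower number that less compound is tolerated. Compound 1 `CC(CCNC(=O)c1c(Cl)cncc1Cl)N1CCC(C(Oc2cccc(C(F)(F)F)c2)c2ccc(C(F)(F)F)cc2)CC1` gives 7000 nM in this assay. Compound 2 `CCO/N=C(/c1ccc(Br)cc1)C1CCN(C(C)(C)CCNC(=O)c2c(Cl)cncc2Cl)CC1` gives 34000 nM in this assay. Of the two values, compound 1 stands lower, so less of it is tolerated than of compound 2, and the gap between them lies beyond the usual scatter of repeated measurements.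

Compound 3 `CC(CCNC(=O)c1c(Cl)cncc1Cl)N1CCC(C(Oc2cccc(Cl)n2)c2ccc(C(F)(F)F)cc2)CC1` is not yet measured. It differs from compound 1 in one place: 6-chloropyridin-2-yl in place of 3-(trifluoromethyl)phenyl on an oxygen on a saturated carbon. The rest of the shared core is unchanged.

Going by the values given here, no step between two measured compounds covers this change, so nothing in the measured pair speaks directly to it. The expectation rests only on compound 1 at 7000 nM as the starting point and on the change itself. A modest upward step is expected, a 1.4-fold higher number from compound 1 to compound 3 (0.15 log units; within the scatter), close to the edge of the scatter rather than clearly beyond it. For compound 3 the estimate in this assay is 10000 nM, with a range from 4000 nM to 25000 nM.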

Compound 3, half-maximal cytotoxic concentration: > 32500 nM
Compound 3 gave a limit, no number; the forecaster's own chance of this, stated with the estimate: 10%; middle value at least 3.2-fold (0.51 log units) from the limit.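

The aryl group on an oxygen on a saturated carbon now has its first reading in the series: 6-chloropyridin-2-yl in place of 3-(trifluoromethyl)phenyl gives an at least 4.6-fold higher number from compound 1 to compound 3 (0.66 log units; beyond the scatter). In this assay this single change, with the rest of the shared core unchanged, therefore moves the result beyond the scatter, which the earlier pair could not show, as those two compounds differ in more than one place. Compound 3 stands at a limit of the assay and not at a number, so the step fixes only a minimum size and its true size remains unknown: the limit of > 32500 nM in this assay, at which 1 of the 3 values shown sits.

The change alters the ring and its substituent together, so the compounds shown do not separate the effect of the ring nitrogen from that of chlorine replacing trifluoromethyl; a chlorophenyl group and a trifluoromethylpyridinyl group on the same oxygen would divide the two. Also open, as far as these compounds go, is whether the step carries over to other groups at this place, such as a pyridine ring bearing an amine or a carboxylic acid.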